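This account rests on a few compounds, and the source may have more. Where it says the series, first, only, none or still open, it means among the compounds named here.

Working notes on the series, values in a functional assay on PC-3 cells (Homo sapiens) for cytotoxicity, read by MTT assay, with a stated time of 48 h; on this read-out higher numbers stand for weaker inhibition and lower numbers for stronger inhibition:

- compound 1 `COc1cc(-n2c(-c3ccc(O)cc3)c[nH]c2=O)cc(OC)c1OC`: 30200 nM
- compound 2 `COc1ccc(-c2c[nH]c(=O)n2-c2cc(OC)c(OC)c(OC)c2)cc1N`: 49800 nM
- compound 3 `COc1cc(NC(=O)n2cc(-c3ccc(O)cc3)n(-c3cc(OC)c(OC)c(OC)c3)c2=O)cc(OC)c1OC`: 3000 nM

Compound 3 has the lowest number of the three in this assay, and compound 1 and compound 2 both lie beyond the scatter from it, on the higher side. The next compound, compound 4 `COc1ccc(-c2cn(C(=O)Nc3cc(OC)c(OC)c(OC)c3)c(=O)n2-c2cc(OC)c(OC)c(OC)c2)cc1O`, keeps everything in compound 3 except one aryl group: 3-hydroxy-4-methoxyphenyl in place of 4-hydroxyphenyl on an aromatic carbon.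

Among the measured compounds shown here, one measured step bears on this change. In a 1.6-fold higher number from compound 1 to compound 2 (0.22 log units; within the scatter), 3-amino-4-methoxyphenyl replaces the same 4-hydroxyphenyl at the same place, and that step stays within the scatter. For the measured compounds named here, it is only a partial guide, as compound 1 and compound 2 lack the larger trimethoxyphenyl amide group present in compound 3, and no measured pair shows this aryl swap with that group in place. No step beyond the scatter is therefore expected in this assay, and no direction is firmly supported. The expected step is a 1.2-fold lower number from compound 3 to compound 4 (0.08 log units; within the scatter). For compound 4 the estimated value is 2500 nM, with an expected range from 700 nM to 9000 nM.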

Compound 4, half-maximal inhibitory concentration: > 50000 nM
Compound 4: only a limit was reported (the forecaster's own chance of this, stated with the estimate: 3%); middle value at least 20-fold (1.30 log units) away from the limit.
By their numbers in this assay, from the lowest: compound 3; then compounds 1 and 2 (each within the scatter of the next). At a limit, above all of these: compound 4.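

In this assay, placing 3-hydroxy-4-methoxyphenyl in place of 4-hydroxyphenyl, on the aromatic carbon next to the ring atom that bears a 3,4,5-trimethoxyphenyl group, gives an at least 16-fold higher number from compound 3 to compound 4 (1.22 log units; beyond the scatter). The earlier step at this place, a 1.6-fold higher number from compound 1 to compound 2 (0.22 log units; within the scatter), involved 3-amino-4-methoxyphenyl and lacked the trimethoxyphenyl amide group, so it gave no sign that this position could be so sensitive to the aryl group in compound 3. For compound 4 the reported value is a limit and not a number, so the step sets only a minimum for the change, and its full size stays unknown because of that limit: the limit of > 50000 nM in this assay, at which 1 of the 4 values shown sits.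

The compounds shown do not separate the contribution of the hydroxy group from that of the methoxy group in the entering aryl, and a plain phenyl group at this place, with the amide group kept, would bear on that question. They also leave open whether 3-hydroxy-4-methoxyphenyl behaves the same way on the core of compound 1, without the amide group, so the part played by that group in this change remains unresolved.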